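Two ring amines and an open chain on a shared core

The source may hold more compounds than are shown below. What is called first, only, known or untested is meant among the compounds shown, and "the series" means these compounds.

Compound 1 `COc1cc2nc(N3CCC(N4CCCC4)CC3)nc(NCc3ccccc3)c2cc1OC` gives < 0% in an in vitro assay on B300-19 cells for displacement of a labelled ligand from C-C chemokine receptor type 4 (Homo sapiens), tested at 1 uM; a higher number here means more inhibition at the concentration tested (going by the name of the read-out), a lower number less inhibition; that figure is a limit of the assay, not a number.
Compound 2 `COc1cc2nc(N3CCC(N4CCCC4)CC3)nc(N3CCCCC3)c2cc1OC` gives 19% in this assay.

Among the measured compounds shown here, compound 2 is thus the only compound with a measured number in this assay. For compound 1 the value is a limit (the limit of < 0% in this assay, at which 1 of the 2 values shown sits).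

Compound 3 `CCNc1nc(N2CCC(N3CCCC3)CC2)nc2cc(OC)c(OC)cc12` differs from compound 2 by ethylamino in place of piperidin-1-yl on an aromatic carbon. For the measured compounds named here, the single measured step bears on it: a number at least 19 percentage points higher from compound 1 to compound 2 (beyond the scatter) went from an amine with no ring to piperidin-1-yl, and the change to compound 3 runs the other way, back to an amine with no ring. A drop beyond the scatter is therefore expected, a number 14 percentage points lower from compound 2 to compound 3 (beyond the scatter). Compound 3 is estimated at 5%, within -10% to 25%.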

Compound 3, a percentage reported as inhibition, at one concentration (the size of the read-out at that concentration, not a potency): < 0%
Compound 3: no number, only a limit (the forecaster's own chance of this, stated with the estimate: 40%); at least 5 percentage points between middle value and limit.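

Ethylamino in place of piperidin-1-yl on this aromatic carbon gives a number at least 19 percentage points lower from compound 2 to compound 3 (beyond the scatter) and shows that the short open chain fares no better here than benzylamino. Of the three groups shown at this position, only piperidin-1-yl gives a measured number, while compound 1 and compound 3 both stand at a limit, so the step between them cannot be read: the limit of < 0% in this assay, at which 2 of the 3 values shown sit.

Piperidin-1-yl differs from ethylamino in both its ring and its missing hydrogen-bond donor, so the compounds shown do not separate the two. Dimethylamino, with no ring and no donor, and morpholin-4-yl, a different ring amine, remain open.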